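Methyl in place of cyclopropyl in the series

The source may report more compounds than this note shows. Statements on the series, on what has been measured and on what is new or still open speak of the compounds shown alone.

Measured in an ADME assay (liver) for metabolic stability, with Liver microsome (Rattus norvegicus) as the target, read by LC-MS, using microsomes, with a stated time of 30 min, tested at 4 uM; on this read-out higher numbers stand for a more stable compound and lower numbers for a less stable compound:
- compound 1 `Cc1nc(N2CCN(C)CC2)c2nc(-c3cccc(C(F)(F)F)c3)n(C3CCOCC3)c2n1`: 28%
- compound 2 `Cc1nc(N2CCN(C)CC2)c2nc(-c3ccccc3C3CC3)n(C3CCOCC3)c2n1`: 67%

Compound 2 stands highest of the two measured compounds at 67%. The next compound to consider is compound 3 `Cc1nc(N2CCN(C)CC2)c2nc(-c3ccccc3C)n(C3CCOCC3)c2n1`, which carries methyl in place of cyclopropyl on an aromatic carbon. This places methyl in place of cyclopropyl on an aromatic carbon, ortho to a large group. Going by the values given here, only one measured step bears on it: a number 39 percentage points higher from compound 1 to compound 2 (beyond the scatter), with 2-cyclopropylphenyl in place of 3-(trifluoromethyl)phenyl. Among the compounds with values here, that step replaces a different group, so it gives only indirect guidance, and no measured pair compares methyl with cyclopropyl directly. A slight fall, not beyond the scatter, is therefore expected, and the uncertainty is wide. The expected step in this assay is a number 7 percentage points lower from compound 2 to compound 3 (within the scatter). For compound 3 the estimated value is 60%, with an expected range from 40% to 76%.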

Compound 3, percent of the compound remaining: 39%
The estimate for compound 3 lay 21 percentage points above the measured number; measured number below the stated range.
By their numbers in this assay, from the lowest: compound 1; then compound 3; then compound 2.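

Replacing cyclopropyl with methyl on an aromatic carbon ortho to a large group is not neutral in this assay: the change gives a number 28 percentage points lower from compound 2 to compound 3 (beyond the scatter), so this pair shows that the group at this place alone moves the read-out. The 2-methylphenyl group still compares favourably with 3-(trifluoromethyl)phenyl, with a number 11 percentage points higher from compound 1 to compound 3 (beyond the scatter), which places it between the other two aryl groups and shows that 2-cyclopropylphenyl accounts for more of the rise than 2-methylphenyl does. Nothing at hand explains why the two groups differ in this way.

From the compounds shown here alone, whether a larger carbon group such as isopropyl or tert-butyl would match or exceed cyclopropyl at this place remains open, as does the outcome with an oxygen-linked group such as methoxy. The compounds shown also leave position and group entangled, and 2-(trifluoromethyl)phenyl would separate the two.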